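Swapping a methyl for 4-chlorophenyl on the shared core

The source may report more compounds than this note shows. Statements on the series, on what has been measured and on what is new or still open speak of the compounds shown alone.

Measured so far:
- compound 1, `Cc1ccc2[nH]c(-n3[nH]c(C)c(Cc4ccccc4)c3=O)nc2c1`: 670 nM
- compound 2, `Cc1ccc2[nH]c(-n3[nH]c(C)c(Cc4ccc(C(F)(F)F)cc4)c3=O)nc2c1`: 570 nM
- compound 3, `Cc1ccc2[nH]c(-n3[nH]c(C)c(C)c3=O)nc2c1`: 2600 nM

These three compounds were tested in an assay on isolated protein for inhibition of alpha-ketoglutarate-dependent dioxygenase alkB homolog 3 (Homo sapiens), read by polymerase chain reaction, with a stated time of 1 h; on this read-out lower numbers stand for stronger inhibition and higher numbers for weaker inhibition. Compound 1 gives 670 nM, which places it second highest of the three numbers. Its nearest neighbour is compound 2, with a 1.2-fold lower number from compound 1 to compound 2 (0.07 log units; within the scatter), a change too small to rank the two. Its furthest is compound 3, with a 3.9-fold higher number from compound 1 to compound 3 (0.59 log units; beyond the scatter).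

Compound 4, `Cc1[nH]n(-c2nc3cc(-c4ccc(Cl)cc4)ccc3[nH]2)c(=O)c1Cc1ccccc1`, has not been measured. It differs from compound 1 in a single place: 4-chlorophenyl in place of methyl on an aromatic carbon. The new group sits on an aromatic carbon of the shared core, meta to a fused ring and para to a fused ring.

Neither measured step touches this position. The step from compound 1 to compound 2 alters the benzyl group, and the step from compound 1 to compound 3 removes the phenyl of that benzyl group. Among the compounds with values here, no measured step therefore speaks directly to a change on the core, and there is no basis for expecting a step beyond the scatter in this assay in either direction. The expected number for compound 4 is 550 nM, with a range from 150 nM to 2000 nM. This estimate corresponds to a 1.2-fold lower number from compound 1 to compound 4 (0.09 log units; within the scatter), which is expected to fall within the scatter.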

Compound 4, half-maximal inhibitory concentration: 1500 nM
Beside the measured number, compound 4's estimate is 2.7-fold (0.44 log units) below it; measured number inside the range.
By their numbers in this assay, from the lowest: compounds 2 and 1 (each within the scatter of the next); then compounds 4 and 3 (each within the scatter of the next).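

This is the first change to the shared core among these compounds, and in this assay it gives a 2.2-fold higher number from compound 1 to compound 4 (0.35 log units; beyond the scatter), so this aromatic carbon is not indifferent to what it carries, as a step beyond the scatter means weaker inhibition here. The step is still only modest, even though a single-carbon methyl gives way to a 4-chlorophenyl of seven heavy atoms that brings a whole extra aromatic ring, so a much larger group at this position does not abolish inhibition. Nothing available explains the rise in the number, and a single replacement cannot separate the contribution of the new ring from that of its chlorine.

The compounds shown leave open how a plain phenyl without the chlorine, a bare hydrogen, or a small group such as methoxy or an amine would behave on this same aromatic carbon, and so whether the trend follows the size of the group or something specific to 4-chlorophenyl. They also leave open whether 4-chlorophenyl on the core would give a similar step when combined with the trifluoromethyl-bearing benzyl group of compound 2.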